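Restoring the cyclobutyl ring in a fluorinated EP4 agonist

The compounds below may be only part of what the source reports. "The series", "measured", "known", "first", "only" and "open" are said of these compounds alone.

Compound 2 `CC(C)(CCCCF)[C@H](O)/C=C/[C@H]1COC(=O)N1CCSc1nc(C(=O)O)cs1` gives 1220 nM in an assay on isolated protein for agonist activity at prostaglandin E2 receptor EP4 subtype (Homo sapiens) (on this read-out higher numbers stand for an effect only at larger amounts of compound and lower numbers for an effect already at smaller amounts), the higher of the two numbers recorded so far. For the measured compounds named here, its only measured neighbour, compound 1 `CCCCC1([C@H](O)/C=C/[C@H]2COC(=O)N2CCSc2nc(C(=O)O)cs2)CCC1`, gives 73 nM in this assay, and the one-place change between them, 5-fluoro-1,1-dimethylpentyl in place of 1-butylcyclobutyl, produced a 17-fold higher number from compound 1 to compound 2 (1.22 log units; beyond the scatter). Compound 3 `O=C(O)c1csc(SCCN2C(=O)OC[C@@H]2/C=C/[C@@H](O)C2(CCCCF)CCC2)n1` differs from compound 2 in exactly that region: 1-(4-fluorobutyl)cyclobutyl in place of 5-fluoro-1,1-dimethylpentyl on a saturated chain carbon bound to a double-bonded chain carbon and an oxygen on a saturated carbon. This returns the four-membered ring of compound 1 while keeping the fluorine at the end of the chain, so the step is close to a reversal of the large upward step from compound 1 to compound 2. Going by the values given here, a substantial downward step is therefore expected, back toward the number seen for compound 1, though the fluorine remains and no measured pair isolates its own contribution. Compound 3 is expected to give about 120 nM in this assay, within roughly 40 nM to 400 nM, meaning an expected step of a 10-fold lower number from compound 2 to compound 3 (1.01 log units; beyond the scatter).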

Compound 3, half-maximal effective concentration: 195 nM
Compound 3: middle estimate off by 1.6-fold (0.21 log units), on the low side, and the stated range covers the measured number.
By their numbers in this assay, from the lowest: compound 1; then compound 3; then compound 2.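

With the fluorine kept, 1-(4-fluorobutyl)cyclobutyl in place of 5-fluoro-1,1-dimethylpentyl gives a 6.3-fold lower number from compound 2 to compound 3 (0.80 log units; beyond the scatter) in this assay, so the four-membered ring matters at this position on its own. With the ring kept, fluoro in place of hydrogen at the end of the chain gives a 2.7-fold higher number from compound 1 to compound 3 (0.43 log units; beyond the scatter) in the same test, so the fluorine also shifts the number by itself. Both steps lie beyond the scatter, which means the large rise seen earlier, where ring and fluorine changed together, combined two changes that each move the number.

Nothing measured here explains either step. Also open, going by these compounds, is whether a cyclopentyl ring, or a chlorine or a hydroxyl group at the end of the chain, would land nearer compound 1 or compound 2.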